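A few compounds are considered here, and "the series" means these few. Any claim that something is new, unique, unknown or untested is made for them only; others in the source may bear on it.

Compound 1 `CCCCn1cnc2c(Nc3cccc(Cl)c3)nc(NCOCc3ccc(/C=C/C(=O)Nc4ccccc4N)cc3)nc21` carries a butyl group on the shared core; in a functional assay on HepG2 cells (Homo sapiens) for antiproliferative activity, read by CCK-8 assay, with a stated time of 72 h, tested at 2 uM (on this read-out lower numbers stand for a weaker effect and higher numbers for a stronger effect at the one concentration tested), compound 1 gives 20.5%. Compound 2 `Nc1ccccc1NC(=O)/C=C/c1ccc(COCNc2nc(Nc3cccc(Cl)c3)c3ncn(C4CCCC4)c3n2)cc1` is built from it by cyclopentyl in place of butyl on an aromatic nitrogen; in this assay compound 2 gives 9.67%, so that the step of a number 10.8 percentage points lower from compound 1 to compound 2 (beyond the scatter) is a modest loss. Compound 3 `CCCCn1cnc2c(Nc3ccccc3)nc(NCOCc3ccc(/C=C/C(=O)Nc4ccccc4N)cc3)nc21` keeps the butyl group; in this assay compound 3 gives 27.9%, and the step of a number 7.4 percentage points higher from compound 1 to compound 3 (within the scatter) says little on its own.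

Compound 4 `Nc1ccccc1NC(=O)/C=C/c1ccc(COCNc2nc(Nc3ccccc3)c3ncn(C4CCCC4)c3n2)cc1` has not yet been measured. It arises from compound 3 by cyclopentyl in place of butyl on an aromatic nitrogen. The place of this change is described in exactly the same words as for the pair compound 1 and compound 2, so it is the same change, carried out on the core of compound 3 instead of the core of compound 1; the two cores differ by hydrogen in place of chloro on an aromatic carbon.

Because a number 10.8 percentage points lower from compound 1 to compound 2 (beyond the scatter) lowered the read-out by a modest amount on the core that carries the chloro group, compound 4 is expected to fall from compound 3 by a similar amount, a number 10.9 percentage points lower from compound 3 to compound 4 (beyond the scatter). This expectation rests on one earlier step only, and nothing shows whether the chloro group changes the outcome of swapping the butyl for the cyclopentyl. Compound 4 is therefore estimated at 17% in this assay, with a plausible range from 5% to 30%.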

Compound 4, a percentage reported as inhibition, at one concentration (the size of the read-out at that concentration, not a potency): 2.93%
Compound 4: middle estimate off by 14.1 percentage points, on the high side; the whole stated range lies above it.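

In this assay the swap of butyl for cyclopentyl on the core without the chloro group gives a number 25 percentage points lower from compound 3 to compound 4 (beyond the scatter) and so keeps the direction seen on the core with the chloro group, but not the size: the same change on two cores in this assay, a number 10.8 percentage points lower (beyond the scatter) from compound 1 to compound 2 and a number 25 percentage points lower (beyond the scatter) from compound 3 to compound 4, 14.1 percentage points apart, beyond the scatter of two such steps. Read the other way, hydrogen in place of chloro gives a number 6.7 percentage points lower from compound 2 to compound 4 (within the scatter) on the core with the cyclopentyl group, so the two changes do not simply add up when they are combined: the same change on two cores in this assay, a number 7.4 percentage points higher (within the scatter) from compound 1 to compound 3 and a number 6.7 percentage points lower (within the scatter) from compound 2 to compound 4, 14.1 percentage points apart, beyond the scatter of two such steps. These two pairs, tested at a single concentration, show that the size of the butyl to cyclopentyl step does not carry over unchanged from one core to the other, but they do not explain why, and they give no rule for any further core.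

The compounds shown leave open how other groups on the aromatic nitrogen, such as methyl, isopropyl, cyclohexyl or a longer chain, would behave on either core. They also leave open whether fluoro or methoxy in place of the chloro group would alter the outcome of the same swap.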